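Trifluoromethyl Ketone Inhibitors: Dropping an Octyl Arm

The compounds below may be only part of what the source reports. "The series", "measured", "known", "first", "only" and "open" are said of these compounds alone.

Measured compounds:
Compound 1, `CCCCCCCCCC(=O)C(F)(F)F`, gives 600 nM in an assay for inhibition of Fatty-acid amide hydrolase 1 (Rattus norvegicus); a lower number here means a stronger inhibitor, a higher number a weaker inhibitor.
Compound 2, `CCCCCCCCc1ccccc1CCCCCCCC(=O)C(F)(F)F`, gives 2500 nM in this assay.

Within the data shown here, of the two numbers recorded in this assay, compound 2 holds the higher one, so it is the weaker inhibitor; its only neighbour is compound 1, whose number is lower by a margin beyond the scatter of the assay. Both compounds share a trifluoromethyl ketone at the end of a long chain, but compound 2 carries a six-membered aromatic ring of carbon only, with an octyl group sitting on it.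

The next compound, compound 3, is `O=C(CCCCCCCc1ccccc1)C(F)(F)F`. It differs from compound 2 in one place: hydrogen in place of octyl on an aromatic carbon. Among the measured compounds shown here, no step between two measured compounds isolates this change, so its effect is not known from the numbers at hand. Compound 3 is expected to give a lower number than compound 2 in this assay, with a step of a 2.5-fold lower number from compound 2 to compound 3 (0.40 log units; beyond the scatter). The estimate rests on compound 1, whose value of 600 nM shows that a compound without the octyl arm can inhibit more strongly. Compound 3 is therefore estimated at 1000 nM, within a range of 300 nM to 4000 nM.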

Compound 3, half-maximal inhibitory concentration: 120 nM
Compound 3: middle estimate off by 8.3-fold (0.92 log units), on the high side; measured number below the stated range.
By their numbers in this assay, from the lowest: compound 3; then compound 1; then compound 2.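

Hydrogen in place of octyl on an aromatic carbon gives a 21-fold lower number from compound 2 to compound 3 (1.32 log units; beyond the scatter) in this assay, a large step showing that the octyl arm at this place on the ring costs a great deal of inhibition. The ring itself carries no such cost: phenyl in place of ethyl on a saturated chain carbon, seven bonds along the chain from a carbonyl carbon, gives a 5.0-fold lower number from compound 1 to compound 3 (0.70 log units; beyond the scatter), a modest step in the favourable direction, so the bare phenyl group improves on the plain chain of compound 1. Nothing at hand explains why either change moves the number as it does.

Going by these compounds, whether a small group such as methyl, methoxy or chlorine on this aromatic carbon would keep the inhibition of compound 3 remains open, as does the question of how much of the octyl arm can stay before the number rises. Also open, on these data alone, is how a shorter or longer chain leading to the trifluoromethyl ketone, or a pyridine ring in place of phenyl, would read in this assay.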